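Same atoms, joined differently: a small step expected

This account rests on a few compounds, and the source may have more. Where it says the series, first, only, none or still open, it means among the compounds named here.

In an ADME assay on a cell-free system (plasma, Rattus norvegicus) for protein binding, compound 1 `Cc1ccn(-c2ccc(Cn3cc(C(=O)O)c(=O)c4c(F)cccc43)cc2)n1` gives 94.3% and compound 2 `O=C(O)c1cn(Cc2ccc(-n3ccc4cnccc43)cc2)c2cccc(F)c2c1=O` gives 96.9%. Among the compounds with values here, these two values lie within the scatter of each other, so the numbers do not separate compound 2 from the only other compound measured so far.

Compound 3 `O=C(O)c1cn(Cc2ccc(-n3ccc4ncccc43)cc2)c2cccc(F)c2c1=O` keeps the shared core and alters one group: a group of 9 heavy atoms (7 carbon, 2 nitrogen; one five-membered aromatic ring with 1 hetero atom, one six-membered aromatic ring with 1 hetero atom) in place of a group of 9 heavy atoms (7 carbon, 2 nitrogen; one five-membered aromatic ring with 1 hetero atom, one six-membered aromatic ring with 1 hetero atom), on an aromatic carbon. The change sits on an aromatic carbon of a six-membered aromatic ring of carbon only, para to a large group. Both groups hold the same atoms, joined differently, so this is a rearrangement rather than an addition.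

Within the data shown here, only one measured step bears on this change, and it exchanged a group of 6 heavy atoms for one of 9 at the same place. That step, a 1.8-fold lower unbound fraction from compound 1 to compound 2 (0.26 log units; within the scatter), gives only limited guidance from a single pair. On that evidence, no step beyond the scatter is expected in this assay, and no direction can be favoured. The estimate amounts to an expected a 1.1-fold higher unbound fraction from compound 2 to compound 3 (0.05 log units; within the scatter). Compound 3 is expected at 96.5%, within an estimated range of 93.5% to 98.5%.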

Compound 3, plasma protein binding: 93%
The estimate for compound 3 lay 2.0-fold (0.30 log units) (unbound fraction) below the measured number; measured number below the stated range.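

In this assay, a group with the same atoms, joined differently, and the same counts of hydrogen-bond donors and acceptors still gives a 2.3-fold higher unbound fraction from compound 2 to compound 3 (0.35 log units; beyond the scatter). This step is modest, yet it shows that at this place, para to a large group, the way the atoms of the group are joined can matter even when its size and atom counts stay the same. The exchange of the smaller group of 6 heavy atoms for this rearranged group gives a 1.2-fold higher unbound fraction from compound 1 to compound 3 (0.09 log units; within the scatter), so that larger group does not by itself separate the two compounds in this assay, and nothing available here gives a reason for the difference between the two arrangements.

On these data alone, with only two arrangements of these atoms compared, it remains open how far other ways of joining them would shift the unbound fraction, and in which direction. As far as these compounds go, it also remains open whether a much simpler group at this place on the aromatic carbon, such as an amine or a longer carbon chain, would stay within the scatter of compound 1 or move clearly away from it.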